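Cyclopentyl Ester in Place of Methyl on a Cardiac Agonist Scaffold

This account rests on a few compounds, and the source may have more. Where it says the series, first, only, none or still open, it means among the compounds named here.

The account concerns a small set of compounds sharing one core and tested in a functional assay (cardiac atrium) for agonist activity, with Cavia porcellus as the target; a higher number here means that more compound is needed for the effect, a lower number that less compound is needed. Compound 1 `CC1=NC(C)=C([N+](=O)[O-])C(c2ccccn2)/C1=C(\O)OC(C)(C)C` gives 1810000 nM in this assay. Compound 2 `CO/C(O)=C1\C(C)=NC(C)=C([N+](=O)[O-])C1c1cccnc1` gives 70000 nM in this assay, and compound 3 `COCCO/C(O)=C1\C(C)=NC(C)=C([N+](=O)[O-])C1c1ccncc1` gives 37700 nM in this assay. Among these three numbers compound 2 stands second highest; its value lies within the scatter of that of compound 3, so no order between those two can be claimed, whereas compound 1 sits well beyond the scatter above it. Compound 1 differs from compound 2 in more than one place, so the gap between them cannot be read as a single step.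

Compound 4 `CC1=NC(C)=C([N+](=O)[O-])C(c2cccnc2)/C1=C(\O)OC1CCCC1` has not yet been measured in this assay. It differs from compound 2 in one place: cyclopentyl in place of methyl on an oxygen on an unsaturated carbon. Within the data shown here, no measured pair in this set isolates such a change, so the direction is uncertain. The higher number of compound 1, which also carries a bulkier ester, is the only hint, and it is confounded. Compound 4 is therefore expected to give roughly 110000 nM in this assay, in a range from 25000 nM to 500000 nM. The estimated step from compound 2 to compound 4 is a 1.6-fold higher number from compound 2 to compound 4 (0.20 log units; within the scatter), a modest rise that may not clear the scatter.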

Compound 4, half-maximal effective concentration: 3280 nM
Compound 4: middle estimate off by 34-fold (1.53 log units), on the high side; measured number below the stated range.
By their numbers in this assay, from the lowest: compound 4; then compounds 3 and 2 (each within the scatter of the next); then compound 1.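

Among these compounds, the exchange of methyl for cyclopentyl on an oxygen on an unsaturated carbon gives the first reading in this set of a change made in one place only: in this assay the move is a 21-fold lower number from compound 2 to compound 4 (1.33 log units; beyond the scatter), a large step in which less compound is needed for the effect once the cyclopentyl group is present. This position is therefore not a silent one, since the group on this oxygen alone can shift the number well beyond the scatter, and a ring of five carbons is accepted here without any loss in the read-out. No measurement at hand accounts for why the number falls with this change.

Going by these compounds, it remains open whether the fall follows the size of the group, and whether an isopropyl group, a cyclohexyl ring or a longer chain such as n-butyl on the same oxygen would give a comparable number. On these data alone, it also remains open whether the same exchange would bring a step of similar size on a compound that differs elsewhere, such as compound 3.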